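The source may report more compounds than this note shows. Statements on the series, on what has been measured and on what is new or still open speak of the compounds shown alone.

The account covers four compounds examined in a physicochemical assay for lipophilicity, measured as octanol-water partition; a lower number here means a more polar compound, a higher number a more lipophilic compound. Compound 1 `CCCc1cn(C/C=C(\C)CCC=C(C)C)nn1` gives 4.5 in this assay. Compound 3 `CCCc1cn(C/C=C(\C)CC/C=C(\C)CCC=C(C)C)nn1` differs from compound 1 by a single change, (3-methylbut-2-en-1-yl in place of hydrogen on a saturated chain carbon bound to a double-bonded chain carbon), and in this assay compound 3 gives 6.5. For the measured compounds named here, that step, a number 2.00 log units higher from compound 1 to compound 3 (beyond the scatter), is the one measured instance of this change. Compound 2 `COC(=O)c1cn(CC=C(C)C)nn1` carries a different core; the difference between the two cores is not broken down here. In this assay compound 2 gives 1.3, the lowest of the three values, sitting well below compound 1 and further still below compound 3, both gaps beyond the scatter.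

Compound 4 `COC(=O)c1cn(C/C=C(\C)CCC=C(C)C)nn1` has not yet been measured in this assay. It differs from compound 2 by 3-methylbut-2-en-1-yl in place of hydrogen on a saturated chain carbon bound to a double-bonded chain carbon, the same change, at the same kind of place, that turns compound 1 into compound 3; it occurs twice among the compounds shown. The expectation for compound 4 rests on compound 3, whose step a number 2.00 log units higher from compound 1 to compound 3 (beyond the scatter) gives the measure of this change. On that basis the same change is expected to give a number 2.00 log units higher from compound 2 to compound 4 (beyond the scatter). Compound 4 is therefore estimated at 3.3, between 2.8 and 3.8.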

Compound 4, partition coefficient: 3.2
Beside the measured number, compound 4's estimate is 0.10 log units above it; the range from low to high includes it.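

In this assay, the change carried to the second core gives a number 1.90 log units higher from compound 2 to compound 4 (beyond the scatter) and so runs in the same direction and is of the same large class as a number 2.00 log units higher from compound 1 to compound 3 (beyond the scatter) on the first core, which shows that 3-methylbut-2-en-1-yl in place of hydrogen gave a closely matching step on both cores. With the chain held fixed, methoxycarbonyl in place of propyl on an aromatic carbon gives a number 1.30 log units lower from compound 1 to compound 4 (beyond the scatter) and accounts for the core difference in this pair. These two instances show nothing about cores beyond the two here, and no measurement bears on why the step carries over.

Still open, going by these compounds, is whether the step would hold with a carboxylic acid or an amine in place of methoxycarbonyl on the aromatic carbon. Also open, on these data alone, is whether a further 3-methylbut-2-en-1-yl on the chain of compound 4 would add a step of like size, or whether the step would change with a longer chain.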